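The source may hold more compounds than are shown below. What is called first, only, known or untested is meant among the compounds shown, and "the series" means these compounds.

Of the compounds shown here, three built on one shared core have been measured so far. In a functional assay on KB cells (Homo sapiens) for antiproliferative activity, read by sulforhodamine B assay, with a stated time of 3 days (on this read-out lower numbers stand for stronger inhibition of growth and higher numbers for weaker inhibition of growth), compound 1 (`COCC(=O)Nc1cccc(Nc2ncc(F)c(Nc3ccc(F)cc3)n2)c1`) gives 6250 nM as its reading, and compound 2 (`Cn1ccnc1NC(=O)c1cccc(Nc2ncc(F)c(Nc3ccc(F)cc3)n2)c1`) gives 14600 nM as its reading. Compound 3 (`COc1cc(NC(=O)c2cccc(Nc3ncc(F)c(Nc4ccc(F)cc4)n3)c2)cc(OC)c1`) gives 15500 nM as its reading, which is level with compound 2 within the scatter, and both of these numbers lie above that of compound 1. The next structure is compound 4 (`O=C(NCCO)c1cccc(Nc2ncc(F)c(Nc3ccc(F)cc3)n2)c1`), and the change leading to it is this: 2-hydroxyethyl in place of 3,5-dimethoxyphenyl on an amide-type nitrogen. Among the compounds with values here, two measured steps bear on it. The closer one changes the group on that same nitrogen, and a 1.1-fold higher number from compound 2 to compound 3 (0.03 log units; within the scatter) stays within the scatter. The other, a 2.3-fold higher number from compound 1 to compound 2 (0.37 log units; beyond the scatter) in size, is modest and involves a larger change to the side arm. As far as these compounds go, the closer step exchanged one ring-bearing group for another, so a group with no ring is untested at this nitrogen and the evidence is thin. The step expected in this assay is therefore small, a 1.3-fold lower number from compound 3 to compound 4 (0.11 log units; within the scatter) as the estimate, with nothing beyond the scatter expected. For compound 4 the estimated value is 12000 nM within an expected range from 4500 nM to 30000 nM on repeat measurement.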

Compound 4, concentration for 50% growth inhibition: 12400 nM
The estimate for compound 4 lay 1.0-fold (0.01 log units) below the measured number, within the range that was stated.
By their numbers in this assay, from the lowest: compounds 1, 4, 2 and 3 (each within the scatter of the next, the first and the last beyond it).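

In this assay, the step of a 1.3-fold lower number from compound 3 to compound 4 (0.10 log units; within the scatter) shows that the ring on the amide-type nitrogen can go entirely: 2-hydroxyethyl, with no ring and 3 heavy atoms, takes the place of 3,5-dimethoxyphenyl, with 10 heavy atoms, and the reading holds, as it also does in the step of a 1.2-fold lower number from compound 2 to compound 4 (0.07 log units; within the scatter), where 2-hydroxyethyl replaces 1-methyl-1H-imidazol-2-yl. Three quite different groups on this nitrogen therefore read level with one another, so across compound 2, compound 3 and compound 4 this position has shown little response to the size of the group or to the presence of a ring, and the step of a 2.0-fold higher number from compound 1 to compound 4 (0.30 log units; within the scatter) places the new amide within the scatter of the side arm of compound 1. No supporting measurement is available to explain why these readings stay so close.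

As far as these compounds go, whether a 2-aminoethyl group, a carboxylic acid or a longer chain such as 3-hydroxypropyl on this nitrogen would move the reading beyond the scatter remains open. Also open, from the compounds shown here alone, is whether any group here could give clearly stronger inhibition of growth than these four compounds show.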